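Exposure of the 2-cyanophenyl analogue in the chlorophenyl series

The compounds below may be only part of what the source reports. "The series", "measured", "known", "first", "only" and "open" are said of these compounds alone.

In an ADME assay on the whole organism for pharmacokinetics, with Mus musculus as the target, at a dose of 10 mg/kg by the oral route (on this read-out lower numbers stand for lower exposure and higher numbers for higher exposure at the dose given), compound 1 (`CC/C(=C(/c1ccc(/C=C/C(=O)O)cc1)c1ccc2[nH]ncc2c1)c1ccccc1Cl`) gives 15000 ng.h/mL and compound 2 (`CC/C(=C(/c1ccc(/C=C/C(=O)O)cc1)c1ccc2[nH]ncc2c1)c1cccc(Cl)c1`) gives 11000 ng.h/mL so compound 2 stands within the scatter of compound 1. Compound 3 (`CC/C(=C(/c1ccc(/C=C/C(=O)O)cc1)c1ccc2[nH]ncc2c1)c1ccccc1C#N`) carries 2-cyanophenyl in place of 3-chlorophenyl on a double-bonded chain carbon bound to a double-bonded chain carbon and a saturated chain carbon. Among the compounds with values here, the one measured step at this place is a 1.4-fold lower number from compound 1 to compound 2 (0.13 log units; within the scatter) and no 2-cyanophenyl compound has a value yet. No step beyond the scatter is therefore expected in this assay for this change. The expected step is a 1.1-fold higher number from compound 2 to compound 3 (0.04 log units; within the scatter) and stays within the scatter. Compound 3 is estimated at 12000 ng.h/mL with an expected range from 5000 ng.h/mL to 26000 ng.h/mL in this read-out.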

Compound 3, area under the concentration-time curve: 200 ng.h/mL
The estimate for compound 3 lay 60-fold (1.78 log units) above the measured number, and the stated range ends above it.
By their numbers in this assay, from the lowest: compound 3; then compounds 2 and 1 (each within the scatter of the next).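

In this assay, the group at this chain carbon matters far more than the chlorophenyl pair indicated: 2-cyanophenyl in place of 3-chlorophenyl gives a 55-fold lower number from compound 2 to compound 3 (1.74 log units; beyond the scatter), and cyano in place of chloro on an aromatic carbon gives a 75-fold lower number from compound 1 to compound 3 (1.88 log units; beyond the scatter). The tolerance seen in a 1.4-fold lower number from compound 1 to compound 2 (0.13 log units; within the scatter) therefore covers the two chlorophenyl groups only and does not extend to the nitrile. Nothing available bears on the cause of this drop.

From the compounds shown here alone, whether the loss is particular to cyano remains open. A methyl or methoxy on the same aromatic ring could separate that question.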